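The compounds below may be only part of what the source reports. "The series", "measured", "known", "first", "only" and "open" are said of these compounds alone.

Compound 1 `O=C1Nc2ccc(Cl)cc2/C1=C/c1cccc(OCc2cn(Cc3ccccc3)nn2)c1` was not assigned a number in a functional assay on HeLa cells (Homo sapiens) for inhibition, read by MTT assay, with a stated time of 48 h (a lower number here means a stronger inhibitor, a higher number a weaker inhibitor), and stands only as "not determined" (no result reported). Compound 2 `O=C1Nc2ccc(C(=O)c3ccccc3)cc2/C1=C\c1cccc(OCc2cn(Cc3ccccc3)nn2)c1` reaches only the limit of this assay in this assay, giving > 50000 nM; that value is a limit rather than a number. So the one fixed point here is the limit of > 50000 nM in this assay, at which 1 of the 2 values shown sits. Compound 3 `COc1ccc(Cc2ccc3c(c2)/C(=C/c2cccc(OCc4cn(Cc5ccccc5)nn4)c2)C(=O)N3)cc1` carries 4-methoxybenzyl in place of chloro on an aromatic carbon. For the measured compounds named here, no measured step supports the size of this change, so only a weak-inhibitor expectation can be framed. Compound 3 is expected to give about 30000 nM in this assay, within 5000 nM to 100000 nM.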

Compound 3, half-maximal inhibitory concentration: 7700 nM
Compound 3: the middle estimate sits 3.9-fold (0.59 log units) above what was measured; low and high end bracket the measured number.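

For the compounds shown here, no step can be read from compound 1, compound 2 or compound 3, as no pair of them offers two firm numbers. As far as these compounds go, how far replacing chloro with 4-methoxybenzyl shifts the result in this assay stays open.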